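The source may report more compounds than this note shows. Statements on the series, on what has been measured and on what is new or still open speak of the compounds shown alone.

In an assay on isolated protein for inhibition of Rho-associated protein kinase 1 (Homo sapiens), read by scintillation counting, radiometric assay and 33P incorporation, with a stated time of 40 min, in the presence of a further agent that is not named here (a lower number here means a stronger inhibitor, a higher number a weaker inhibitor), compound 3 `N#Cc1ccc(C(=O)Nc2cccc(NC(=O)COc3ccc4c(=O)ccoc4c3)c2)cc1` gives 123 nM, which places it within the scatter of the other two numbers: compound 1 `O=C(COc1ccc2c(=O)ccoc2c1)Nc1cccc(NC(=O)c2ccccc2)c1` gives 120 nM, and compound 2 `CCc1ccc(C(=O)Nc2cccc(NC(=O)COc3ccc4c(=O)ccoc4c3)c2)cc1` gives 235 nM. Compound 4 `Cc1cc(C(=O)Nc2cccc(NC(=O)COc3ccc4c(=O)ccoc4c3)c2)ccc1C(F)(F)F` differs from compound 3 by a group of 11 heavy atoms (8 carbon, 3 fluorine; one six-membered aromatic ring of carbon only) in place of a group of 8 heavy atoms (7 carbon, 1 nitrogen; one six-membered aromatic ring of carbon only), on a carbonyl carbon. Three earlier changes on the same carbonyl-linked ring bear on this: a 1.0-fold higher number from compound 1 to compound 3 (0.01 log units; within the scatter), a 1.9-fold lower number from compound 2 to compound 3 (0.28 log units; within the scatter) and a 2.0-fold higher number from compound 1 to compound 2 (0.29 log units; within the scatter), all within the scatter. Substituents on that ring have so far moved this assay little, so the step of a 1.3-fold higher number from compound 3 to compound 4 (0.11 log units; within the scatter) is expected to stay within the scatter as well. Compound 4 is therefore estimated at 160 nM, with a range of 60 nM to 450 nM.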

Compound 4, half-maximal inhibitory concentration: 460 nM
Estimate against measurement, compound 4: 2.9-fold (0.46 log units) below; measured number above the stated range.
By their numbers in this assay, from the lowest: compounds 1, 3, 2 and 4 (each within the scatter of the next, the first and the last beyond it).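

Among these compounds, on the ring attached to the carbonyl carbon, this replacement gives the first changes beyond the scatter in this assay: a 3.7-fold higher number from compound 3 to compound 4 (0.57 log units; beyond the scatter) and a 3.8-fold higher number from compound 1 to compound 4 (0.58 log units; beyond the scatter), both modest. Compound 2 does not fit a clean split, since a 2.0-fold higher number from compound 2 to compound 4 (0.29 log units; within the scatter) stays within the scatter, as do its steps to compound 1 and compound 3. Nothing measured here explains the weaker inhibition of compound 4. From the compounds shown here alone, compound 4 carries a methyl and a trifluoromethyl together, so the share of each remains open. Going by these compounds, how an amine or a carboxylic acid on this ring would behave also remains open.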